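Aryl swap on an adenosine receptor core: compound 4

The source may report more compounds than this note shows. Statements on the series, on what has been measured and on what is new or still open speak of the compounds shown alone.

Measured so far, in an assay on CHO cells for displacement of a labelled ligand from adenosine receptor A3 (Homo sapiens), read by scintillation counting, with a stated time of 3 h; a lower number here means a stronger inhibitor, a higher number a weaker inhibitor:
- compound 1 `Cn1c(-c2ccc(F)cc2)nc2c(NC3CCCC3)ncnc21` gives 1140 nM
- compound 2 `COc1ccc(-c2nc3c(NC4CCCC4)ncnc3n2C)cc1` gives 1850 nM
- compound 3 `Cn1c(-c2cccnc2)nc2c(NC3CCCC3)ncnc21` gives 11000 nM

Compound 3 has the highest number of the three in this assay, so it is the weakest inhibitor here; its steps to compound 2 and to compound 1 both lie beyond the scatter. Compound 4 `Cc1ccccc1-c1nc2c(NC3CCCC3)ncnc2n1C` differs from compound 3 in one place: 2-methylphenyl in place of pyridin-3-yl on an aromatic carbon.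

Going by the values given here, two measured steps bear on this change, since both run from a carbon-only ring to the pyridin-3-yl ring of compound 3: a 9.6-fold higher number from compound 1 to compound 3 (0.98 log units; beyond the scatter) and a 5.9-fold higher number from compound 2 to compound 3 (0.77 log units; beyond the scatter). Going the other way, from pyridin-3-yl back to a carbon-only ring, the expectation is therefore a lower number, of modest size, for compound 4. Among the compounds with values here, the 2-methylphenyl group has no measured counterpart, so the expected step of a 5.5-fold lower number from compound 3 to compound 4 (0.74 log units; beyond the scatter) carries a wide range. Compound 4 is estimated at 2000 nM, with a range from 700 nM to 6000 nM.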

Compound 4, inhibition constant: 3000 nM
The estimate for compound 4 lay 1.5-fold (0.18 log units) below the measured number, within the range that was stated.
By their numbers in this assay, from the lowest: compounds 1, 2 and 4 (each within the scatter of the next, the first and the last beyond it); then compound 3.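

The lower number on leaving pyridin-3-yl now holds for a third carbon-only ring, since 2-methylphenyl gives a 3.7-fold lower number from compound 3 to compound 4 (0.56 log units; beyond the scatter) in this assay and joins 4-fluorophenyl and 4-methoxyphenyl on that side of compound 3. The carbon-only rings are not all alike, however: the comparison with 4-methoxyphenyl shows a 1.6-fold higher number from compound 2 to compound 4 (0.21 log units; within the scatter) and the comparison with 4-fluorophenyl shows a 2.6-fold higher number from compound 1 to compound 4 (0.42 log units; beyond the scatter) and so the choice among such rings can still shift the number modestly. No measurement given here accounts for these differences.

The compounds shown leave open whether any group at this position could bring the number far below those of the carbon-only rings. A phenyl ring bearing an amine or a carboxylic acid, or a longer alkyl chain in place of the ring, would test how much further this position can be pushed.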